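Swapping the urea-bearing tail for a benzyl group

A few compounds are considered here, and "the series" means these few. Any claim that something is new, unique, unknown or untested is made for them only; others in the source may bear on it.

In an ADME assay on cells (Homo sapiens) for cytotoxicity, read by polymerase chain reaction, with a stated time of 3 days (on this read-out higher numbers stand for lower toxicity in this test and lower numbers for higher toxicity in this test), compound 1 `CCNc1nc(C)c(-c2nc3ccccc3s2)c(N[C@@H]2C[C@H](CO)[C@@H](O)[C@H]2O)n1` gives 12000 nM and compound 2 `CCOC(=O)NCCNc1nc(C)c(-c2nc3ccccc3s2)c(N[C@@H]2C[C@H](CO)[C@@H](O)[C@H]2O)n1` gives 12000 nM, with no change at the digits printed from compound 1 to compound 2 (within the scatter). Compound 3 `Cc1nc(NCCNC(=O)NC(C)(C)C)nc(N[C@@H]2C[C@H](CO)[C@@H](O)[C@H]2O)c1-c1nc2ccccc2s1` is known in this assay only by a limit, > 25000 nM; this is the limit of > 25000 nM in this assay, at which 1 of the 3 values shown sits. From those numbers, an at least 2.0-fold higher number from compound 1 to compound 3 (0.31 log units; beyond the scatter) and an at least 2.0-fold higher number from compound 2 to compound 3 (0.31 log units; beyond the scatter), so compound 3 stands at the least toxic end of the measured set in this assay, though only a limit marks where it lies.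

Compound 4 `Cc1nc(NCc2ccccc2)nc(N[C@@H]2C[C@H](CO)[C@@H](O)[C@H]2O)c1-c1nc2ccccc2s1` differs by phenyl in place of (((tert-butyl)carbamoyl)amino)methyl on a saturated chain carbon bound to a nitrogen on an aromatic ring. Among the measured compounds shown here, no measured step makes this exact exchange. The nearest guide is the step in which compound 1 carries only an ethyl on that nitrogen and its value sits a step below the limit of compound 3, and compound 2, with a carbamate rather than a urea on the chain, sits at the same place as compound 1. Dropping the urea is therefore expected to bring a lower number, and compound 4 is expected to give about 11000 nM in this assay, within 4000 nM to 25000 nM, a step of an at least 2.2-fold lower number from compound 3 to compound 4 (0.35 log units; beyond the scatter).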

Compound 4, half-maximal cytotoxic concentration: 9000 nM
For compound 4 the middle estimate is 1.2-fold (0.09 log units) above the measured one; low and high end bracket the measured number.
By their numbers in this assay, from the lowest: compounds 4, 1 and 2 (each within the scatter of the next). At a limit, above all of these: compound 3.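

In this assay, phenyl in place of (((tert-butyl)carbamoyl)amino)methyl brings an at least 2.7-fold lower number from compound 3 to compound 4 (0.44 log units; beyond the scatter), so an aromatic ring at this place does not keep the reading of the urea tail. Against the ethyl and carbamate tails the benzyl tail cannot be told apart, with a 1.3-fold lower number from compound 1 to compound 4 (0.12 log units; within the scatter) and a 1.3-fold lower number from compound 2 to compound 4 (0.12 log units; within the scatter), so among these four compounds only the urea tail of compound 3 stands apart. That reading of compound 3 is a limit and not a number: the limit of > 25000 nM in this assay, at which 1 of the 4 values shown sits.

The compounds leave open whether the urea itself or its tert-butyl sets compound 3 apart, and how a benzyl carrying a carboxylic acid would read. On these data alone, how an amine or a longer chain ending in a urea would read at this place also stays open.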